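The source may hold more compounds than are shown below. What is called first, only, known or untested is meant among the compounds shown, and "the series" means these compounds.

The series shares one core, carrying an amide on a carbonyl carbon whose other neighbour is a saturated chain carbon. Compound 1 `CC(C)(C)c1ccc(C(=O)N2CCC3(CC2)C(=O)N(CC(=O)N2CCCC(O)C2)CN3c2ccccc2)cc1` gives 12200 nM in an assay on HEK293 cells for displacement of a labelled ligand from NPC1-like intracellular cholesterol transporter 1 (Homo sapiens); on this read-out lower numbers stand for stronger inhibition and higher numbers for weaker inhibition. Compound 2 `CC(C)(C)c1ccc(C(=O)N2CCC3(CC2)C(=O)N(CC(=O)NCCCCNS(C)(=O)=O)CN3c2ccccc2)cc1` gives 4500 nM in this assay, and compound 3 `CCC1CCCN(C(=O)CN2CN(c3ccccc3)C3(CCN(C(=O)c4ccc(C(C)(C)C)cc4)CC3)C2=O)C1` gives 3900 nM. Compound 3 holds the lowest of the three numbers, but its gap to compound 2 lies within the scatter, so these two are not separated; only compound 1 stands apart, with a 3.1-fold lower number from compound 1 to compound 3 (0.50 log units; beyond the scatter).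

Compound 4 `CC(C)(C)c1ccc(C(=O)N2CCC3(CC2)C(=O)N(CC(=O)N2CCNCC2)CN3c2ccccc2)cc1` is not yet measured. It differs from compound 3 by piperazin-1-yl in place of 3-ethylpiperidin-1-yl on a carbonyl carbon. The two measured steps at this position are a 2.7-fold lower number from compound 1 to compound 2 (0.43 log units; beyond the scatter) and a 1.2-fold lower number from compound 2 to compound 3 (0.06 log units; within the scatter): exchanging the amide substituent has moved the number modestly at most, and the one clear shift came when the hydroxy-bearing ring of compound 1 was exchanged. Compound 4 brings piperazin-1-yl to this position, which in what is counted sits nearer compound 1 than compound 3. A modest rise is expected, a 2.1-fold higher number from compound 3 to compound 4 (0.31 log units; beyond the scatter), not larger than the separation seen from compound 1. Compound 4 is estimated at 8000 nM, in the range 3000 nM to 25000 nM.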

Compound 4, half-maximal inhibitory concentration: 22000 nM
For compound 4 the middle estimate is 2.8-fold (0.44 log units) below the measured one; measured number inside the range.
By their numbers in this assay, from the lowest: compounds 3 and 2 (each within the scatter of the next); then compounds 1 and 4 (each within the scatter of the next).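

With piperazin-1-yl on the carbonyl carbon, this assay gives a clear rise against both better-placed substituents, a 5.6-fold higher number from compound 3 to compound 4 (0.75 log units; beyond the scatter) and a 4.9-fold higher number from compound 2 to compound 4 (0.69 log units; beyond the scatter), so this position can move the number even when the new group is a ring of the same size as 3-ethylpiperidin-1-yl. Compound 1 and compound 4 are not separated, with a 1.8-fold higher number from compound 1 to compound 4 (0.26 log units; within the scatter), so among the three ring amides only the ethyl-bearing ring of compound 3 stands apart, while compound 2, which has an open chain with a sulfonamide in place of a ring, is not separated from compound 3 and shows that a low number here does not depend on that ring. No measurement shown accounts for the rise from compound 3 to compound 4.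

Still open, on these data alone, is whether the higher number of compound 4 follows the ring nitrogen with its hydrogen or the loss of the ethyl group. A plain piperidin-1-yl, a morpholin-4-yl or a 4-methylpiperazin-1-yl on this carbonyl carbon would tell these two changes apart.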